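This account rests on a few compounds, and the source may have more. Where it says the series, first, only, none or still open, it means among the compounds named here.

Measured so far in a functional assay on A549 cells (Homo sapiens) for antiproliferative activity, read by sulforhodamine B assay, with a stated time of 72 h; on this read-out lower numbers stand for stronger inhibition of growth and higher numbers for weaker inhibition of growth:
Compound 1, `Cc1cc(=O)oc2cc(SCc3cccc(C(F)(F)F)c3)ccc12`: > 28500 nM
Compound 2, `Cc1cc(=O)oc2cc(SCc3cccc(C#N)c3)ccc12`: > 32500 nM

Both values are limits of this assay, not numbers. Compound 1 sits at the limit given by the limit of > 28500 nM in this assay, at which 1 of the 2 values shown sits. Compound 2 sits at the limit given by the limit of > 32500 nM in this assay, at which 1 of the 2 values shown sits. The step from compound 1 to compound 2, a step that the two limits leave unreadable from compound 1 to compound 2, therefore has no readable size: both ends are limits, and nothing can be said about its direction or whether it exceeds the scatter. Within the data shown here, compound 2 thus stands at a limit with no number attached, and the single other value shown for the series is likewise a limit.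

Compound 3, `COC(=O)c1cccc(CSc2ccc3c(C)cc(=O)oc3c2)c1`, differs from compound 2 by one change: methoxycarbonyl in place of cyano on an aromatic carbon. Among the measured compounds shown here, the only measured step that bears on this position, from compound 1 to compound 2, is unreadable, so it gives no guide to the size or direction of the step to compound 3 in this assay. With both measured members of the series at limits, compound 3 is expected to give 35000 nM (range 10000 nM to 120000 nM). The step from compound 2 to compound 3 that this estimate implies, a step that the limit leaves unreadable from compound 2 to compound 3, is expected to lie within the scatter, with a high chance that only a limit is reported again.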

Compound 3, concentration for 50% growth inhibition: 7700 nM
Compound 3: the middle estimate sits 4.5-fold (0.66 log units) above what was measured; the whole stated range lies above it.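

In this assay, among these compounds, methoxycarbonyl on this aromatic carbon, meta to a large group, gives the first steps at this position with a readable lower bound: an at least 4.2-fold lower number from compound 2 to compound 3 (0.62 log units; beyond the scatter), and an at least 3.7-fold lower number from compound 1 to compound 3 (0.56 log units; beyond the scatter). Both steps lie beyond the scatter, so this position is not silent in this assay, and the change from either earlier group to methoxycarbonyl does register, though each step has a limit at one end and only its minimum size is known. Among the compounds shown here, compound 1 and compound 2 remain limits rather than numbers, and the step between them cannot be read, so the series still holds only one true number, that of compound 3.

What the compounds shown leave open is which part of methoxycarbonyl carries the step, since the carbonyl and the methoxy part are never separated here; a carboxylic acid, a primary amide or a longer ester chain on the same carbon would begin to divide them. Also open, as far as these compounds go, is whether methoxycarbonyl gives a similar step at any other carbon of this ring, since every group shown sits at the same place.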